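Lengthening the Amide Chain on Compound 1

The compounds below may be only part of what the source reports. "The series", "measured", "known", "first", "only" and "open" are said of these compounds alone.

compound 1 `CC[C@@H]1c2cc(Cl)ccc2C(=O)N1c1cncc2c1CCC[C@H]2NC(C)=O`: 334 nM
compound 2 `CC(=O)N[C@@H]1CCCc2c1cncc2N1C(=O)c2ccc(Cl)cc2[C@H]1C`: 5140 nM
compound 3 `CC(=O)N[C@@H]1CCCc2c1cncc2N1C(=O)c2ccc(Cl)cc2[C@H]1C1CC1`: 22800 nM

In an ADME assay on cells for inhibition of cytochrome P450 11B1, mitochondrial (Homo sapiens), read by HTRF (on this read-out lower numbers stand for stronger inhibition and higher numbers for weaker inhibition), compound 1 stands lowest of the three measured compounds: a 15-fold higher number from compound 1 to compound 2 (1.19 log units; beyond the scatter), a 68-fold higher number from compound 1 to compound 3 (1.83 log units; beyond the scatter), and a 4.4-fold higher number from compound 2 to compound 3 (0.65 log units; beyond the scatter). Compound 4 `CCC(=O)N[C@@H]1CCCc2c1cncc2N1C(=O)c2ccc(Cl)cc2[C@H]1CC` differs from compound 1 by methyl in place of hydrogen on a saturated chain carbon bound to a carbonyl carbon. For the measured compounds named here, every measured step changes the group on a saturated ring carbon; none touches the amide chain, so no measured step speaks directly to this change. A single added carbon at the amide is a small alteration, and the expected step is a 1.3-fold higher number from compound 1 to compound 4 (0.13 log units; within the scatter), a shift that may not exceed the scatter in either direction. Compound 4 is therefore expected to give 450 nM in this assay, with a likely range from 150 nM to 1400 nM.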

Compound 4, half-maximal inhibitory concentration: 10200 nM
The estimate for compound 4 lay 23-fold (1.36 log units) below the measured number, outside the stated range (above it).
By their numbers in this assay, from the lowest: compound 1; then compounds 2 and 4 (each within the scatter of the next); then compound 3.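

The amide chain proves to be a sensitive place in this assay and not a tolerant one: methyl in place of hydrogen on the saturated chain carbon bound to a carbonyl carbon gives a 31-fold higher number from compound 1 to compound 4 (1.48 log units; beyond the scatter) for this one added carbon. The step turns acetamido into propanoylamino, and it shows that the saturated ring carbon is not the only place where a small change has a large effect. Nothing measured here explains this step.

On these data alone, whether a longer chain such as butanoylamino would raise the number further remains open. So does whether an amine or a carboxylic acid on this chain would be tolerated.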